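A few compounds are considered here, and "the series" means these few. Any claim that something is new, unique, unknown or untested is made for them only; others in the source may bear on it.

Among the measured compounds shown here, in an ADME assay on microsomes from liver (Rattus norvegicus) for metabolic stability, with a stated time of 10 min (a lower number here means that less of the compound is left, a higher number that more of the compound is left), compound 1 (`COc1ccc(Nc2nc(Cl)cn([C@H](C)C3CC3)c2=O)c(C)n1`) gives 89%, the higher of the two numbers measured so far, while compound 2 (`COc1ccc(Nc2nc(Cl)cn([C@H](C)C3CC3)c2=O)c(OC)n1`) gives 43%. Compound 3 (`COc1nc(C)c(Nc2nc(Cl)cn([C@H](C)C3CC3)c2=O)cc1C`) keeps the structure of compound 1 with a single change: methyl in place of hydrogen on an aromatic carbon. In words, this is methyl in place of hydrogen on an aromatic carbon, and the new methyl sits ortho to a methoxy group and para to a methyl group.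

For the measured compounds named here, only one measured step is available for comparison, a number 46 percentage points lower from compound 1 to compound 2 (beyond the scatter), which is a large step beyond the scatter. It comes from a different change, methoxy in place of methyl on an aromatic carbon, so it bears on this case only indirectly. It shows that one small swap on this ring can matter, but it does not show what an added methyl will do. A small fall or no change beyond the scatter is therefore expected, and the expected step is a number 9 percentage points lower from compound 1 to compound 3 (within the scatter). The low side of the range stays wide because a number 46 percentage points lower from compound 1 to compound 2 (beyond the scatter) shows how far one swap can move the number. The estimated value for compound 3 is 80%, with an expected range from 55% to 95%.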

Compound 3, percent of the compound remaining: 77%
The estimate for compound 3 lay 3 percentage points above the measured number; measured number inside the range.
By their numbers in this assay, from the lowest: compound 2; then compound 3; then compound 1.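

In this assay, among the compounds shown here, this is the first reading for any change at this aromatic carbon, which lies ortho to a methoxy group and para to a methyl group, and replacing its hydrogen with methyl gives a number 12 percentage points lower from compound 1 to compound 3 (beyond the scatter) as a modest step. The position is therefore not indifferent to substitution, since one added carbon moves the number beyond the usual scatter, though this step is modest while a number 46 percentage points lower from compound 1 to compound 2 (beyond the scatter) is large and comes from a swap at another place on the ring. No measurement at hand speaks to the reason for the step from hydrogen to methyl.

From the compounds shown here alone, it remains open whether any group on this carbon would lower the number or whether the result belongs to methyl alone, and a fluorine, a chlorine, an ethyl or a nitrile there could each give a different answer. Going by these compounds, it also remains open whether the same added methyl would produce a step of similar size on compound 2, where methoxy replaces the methyl group of compound 1.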